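Swapping Methyl for 4-Methylphenyl on a Sulfonyl Sulfur

The compounds below may be only part of what the source reports. "The series", "measured", "known", "first", "only" and "open" are said of these compounds alone.

Values in a physicochemical assay for lipophilicity, read by HPLC, measured as octanol-water partition (on this read-out lower numbers stand for lower lipophilicity and higher numbers for higher lipophilicity), so far stand as follows:
- compound 1 `Cc1ccc(N2C(=O)[C@H](CCCNS(=O)(=O)c3ccc(OC(F)(F)F)cc3)[C@H]2c2ccc([N+](=O)[O-])cc2)cc1` gives >= 4.4 which is a limit of the assay and not a number
- compound 2 `CCc1ccc(S(=O)(=O)NCCC[C@H]2C(=O)N(c3ccc(C)cc3)[C@@H]2c2ccc(NS(=O)(=O)c3ccc(C)cc3)cc2)cc1` gives 3.4 as a measured number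
- compound 3 `Cc1ccc(N2C(=O)[C@H](CCCNS(=O)(=O)c3ccc(OC(F)(F)F)cc3)[C@H]2c2ccc(NS(C)(=O)=O)cc2)cc1` gives 3.4 as a measured number

On these numbers compound 3 stands level with compound 2, with no gap beyond the usual scatter. Compound 4 `Cc1ccc(N2C(=O)[C@H](CCCNS(=O)(=O)c3ccc(OC(F)(F)F)cc3)[C@H]2c2ccc(NS(=O)(=O)c3ccc(C)cc3)cc2)cc1` has not been measured yet. The change from its neighbour is 4-methylphenyl in place of methyl on a sulfonyl sulfur and it puts 4-methylphenyl in place of methyl on a sulfonyl sulfur.

Within the data shown here, the one measured step that touches this part of the series is a number at least 1.00 log units lower from compound 1 to compound 3 (beyond the scatter) and it came with methanesulfonamido in place of nitro on an aromatic carbon. That step lies beyond the scatter, but it swaps a different pair of groups and starts from a limit, so it gives only a loose guide to size. A closer guide is compound 2 with 3.4 in this assay since it already carries ((4-methylphenyl)sulfonyl)amino, though it differs from compound 4 elsewhere. A small rise at most is therefore expected, and the estimated change is a number 0.20 log units higher from compound 3 to compound 4 (within the scatter) in this assay which would not clearly pass the scatter. Compound 4 is expected at 3.6 within an estimated range of 3.1 to 4.3 on this same scale.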

Compound 4, partition coefficient: 3.4
The estimate for compound 4 lay 0.20 log units above the measured number, and the stated range covers the measured number.
By their numbers in this assay, from the lowest: compounds 2, 3 and 4 (each within the scatter of the next). At a limit, above all of these: compound 1.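

On this sulfonyl sulfur, 4-methylphenyl in place of methyl brings in a six-membered aromatic ring and seven heavy atoms where there was one, yet this assay shows no change at the digits printed from compound 3 to compound 4 (within the scatter), and trifluoromethoxy in place of ethyl on an aromatic carbon likewise shows no change at the digits printed from compound 2 to compound 4 (within the scatter). The replacement of nitro on an aromatic carbon by ((4-methylphenyl)sulfonyl)amino is a step beyond the scatter, a number at least 1.00 log units lower from compound 1 to compound 4 (beyond the scatter), so in these compounds the group on the sulfonyl sulfur can grow from methyl to 4-methylphenyl without any readable shift in the number, while the loss of nitro still gives a clear step. The value of compound 1 is a limit of the assay and not a number: the limit of >= 4.4 in this assay, at which 1 of the 4 values shown sits.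

As far as these compounds go, the true size of that step therefore stays open, since only its lower bound can be read. Only methyl and 4-methylphenyl are shown on this sulfur, so it also remains open whether an amine, a carboxylic acid or a longer chain there would leave the number just as unchanged.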